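The source may report more compounds than this note shows. Statements on the series, on what has been measured and on what is new or still open speak of the compounds shown alone.

Measured compounds:
- compound 1 `NCc1ccc(C(=O)Nc2ccncc2F)cc1-c1cccc(C(=O)Oc2ccccc2)c1`: 6.2 nM
- compound 2 `CCCCCCOC(=O)c1cccc(-c2cc(C(=O)Nc3ccncc3)ccc2CN)c1`: 22 nM
- compound 3 `NCc1ccc(C(=O)Nc2ccncc2)cc1-c1cccc(C(=O)OCc2ccccc2)c1`: 45 nM

In an assay on isolated protein for inhibition of Rho-associated protein kinase 2 (Homo sapiens), read by radiometric assay (on this read-out lower numbers stand for stronger inhibition and higher numbers for weaker inhibition), compound 1 gives the lowest number of the three measured compounds, with compound 2 next and compound 3 furthest from it. The unmeasured compound 4 `NCc1ccc(C(=O)Nc2ccncc2F)cc1-c1cccc(C(=O)OCC2CCCO2)c1` differs from compound 1 in one place only: (oxolan-2-yl)methyl in place of phenyl on an oxygen next to a carbonyl group. The ester substituent on the shared core is thus exchanged while everything else is kept. Among the compounds with values here, only one measured step touches this part of the molecule, the change from compound 2 to compound 3, where a 2.0-fold higher number from compound 2 to compound 3 (0.31 log units; beyond the scatter); this shows that swapping one ester substituent for another of similar size moves the number only modestly. Compound 1 and compound 2 differ in two places, so their gap cannot be assigned to the ester alone. For compound 4 a small weakening is therefore expected, about a 1.9-fold higher number from compound 1 to compound 4 (0.29 log units; within the scatter), roughly matching the size seen from compound 2 to compound 3. Compound 4 is expected to give 12 nM, within a range from 4 nM to 40 nM.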

Compound 4, half-maximal inhibitory concentration: 2.5 nM
Compound 4: the middle estimate sits 4.8-fold (0.68 log units) above what was measured, and the stated range ends above it.
By their numbers in this assay, from the lowest: compound 4; then compound 1; then compound 2; then compound 3.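

In this assay, putting (oxolan-2-yl)methyl in place of phenyl on an oxygen next to a carbonyl group gives a 2.5-fold lower number from compound 1 to compound 4 (0.39 log units; beyond the scatter), so a non-aromatic ring carrying a ring oxygen is accepted here on the core of compound 1. Within the data shown here, the only earlier step at this place, a 2.0-fold higher number from compound 2 to compound 3 (0.31 log units; beyond the scatter), went the other way on a different pair, so the number at this position can move in either direction depending on the group and the pair. No separate data are available to explain why the number falls with this exchange.

The compounds shown leave open whether the ring oxygen itself matters, which a cyclopentylmethyl ester would test, and how a carboxylic acid or an amide would fare at this place. They also leave open whether the same exchange gives a similar step on the core of compound 2 and compound 3, which lacks the fluorine.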